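The source may hold more compounds than are shown below. What is called first, only, known or untested is meant among the compounds shown, and "the series" means these compounds.

Working notes on the carbamate series. Compound 1 `COc1nc(C)c(Nc2nc(Cl)cn([C@H](COC(=O)Nc3ccc(Cl)cc3)C3CC3)c2=O)cc1C` is the reference point; in an assay on frontal cortex for displacement of a labelled ligand from corticotropin-releasing factor receptor 1 (Rattus norvegicus), with a stated time of 2 h (on this read-out lower numbers stand for stronger inhibition and higher numbers for weaker inhibition), compound 1 gives 1.6 nM. Compound 2 `COc1nc(C)c(Nc2nc(Cl)cn([C@H](COC(=O)Nc3ccc(Cl)cc3Cl)C3CC3)c2=O)cc1C` carries chloro in place of hydrogen on an aromatic carbon, and in this assay compound 2 gives 1.7 nM. Going by the values given here, the single step so far, a 1.1-fold higher number from compound 1 to compound 2 (0.03 log units; within the scatter), shows that the added chloro leaves the read-out essentially where it was. Compound 2 has the highest of the two numbers, but its nearest neighbour, compound 1, sits within the scatter of it, so no order between the two can be drawn.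

Compound 3 `CCNC(=O)OC[C@H](C1CC1)n1cc(Cl)nc(Nc2cc(C)c(OC)nc2C)c1=O` is the next member. Relative to compound 2 the change is ethyl in place of 2,4-dichlorophenyl on an amide-type nitrogen; cut one bond further out it reads (2,4-dichlorophenyl)carbamoyl to ethylcarbamoyl. Among the compounds with values here, the one measured step alters only a substituent on the aromatic ring and says nothing about removing that ring altogether, so it bears on the new change only weakly. The carbamate terminus has tolerated one alteration without effect in this assay, but the present change is larger in scale. A moderate rise, beyond the scatter, is expected for compound 3, a 2.9-fold higher number from compound 2 to compound 3 (0.47 log units; beyond the scatter). The estimate for compound 3 in this assay is 5 nM, in the range 1.2 nM to 25 nM.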

Compound 3, half-maximal inhibitory concentration: 14 nM
For compound 3 the middle estimate is 2.8-fold (0.45 log units) below the measured one, within the range that was stated.
By their numbers in this assay, from the lowest: compounds 1 and 2 (each within the scatter of the next); then compound 3.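

Unlike the chloro step, which only altered a substituent on the aromatic ring, replacing the whole 2,4-dichlorophenyl with ethyl on the amide-type nitrogen does move the read-out in this assay: the change gives an 8.2-fold higher number from compound 2 to compound 3 (0.92 log units; beyond the scatter), and the matching change from 4-chlorophenyl gives an 8.8-fold higher number from compound 1 to compound 3 (0.94 log units; beyond the scatter). The two steps agree, so this position is not indifferent to what it carries, and the outcome does not depend on which of the two chlorinated phenyl groups is removed, although the shift remains modest and compound 3 still gives 14 nM. No measurement bearing on the reason for this shift is available.

The pair of changes removes the aromatic ring and shortens the substituent together, so the compounds shown cannot separate the two; a cyclohexyl group or a longer chain such as n-hexyl on the same nitrogen would show whether the number stays near those of compound 1 and compound 2 without an aromatic ring. Also open, as far as these compounds go, is how an unsubstituted phenyl or a benzyl group would read here, and whether a chain ending in an amine or a carboxylic acid would be tolerated.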